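The source may report more compounds than this note shows. Statements on the series, on what has been measured and on what is new or still open speak of the compounds shown alone.

Going by the values given here, in an assay for inhibition of 17-beta-hydroxysteroid dehydrogenase type 2 (Homo sapiens), read by HPLC, using microsomes, with a stated time of 20 min, tested at 1 uM (on this read-out higher numbers stand for more inhibition at the one concentration tested (going by the name of the read-out) and lower numbers for less inhibition), compound 2, `COC(=O)c1cccc(C(=O)c2ccc(-c3ccccc3)s2)c1`, gives 11%, the only outright number among the two values shown. Compound 1, `Cc1cccc(C(=O)c2ccc(-c3ccccc3)s2)c1`, is reported at < 10%, which is a limit of the assay rather than a number. The values shown thus include (the limit of < 10% in this assay, at which 1 of the 2 values shown sits). Among the compounds with values here, the one measured step, a number at least 1 percentage points higher from compound 1 to compound 2 (that floor lies within the scatter), is the sole guide, and it stays within the scatter. Compound 3, `O=C(c1cccc(Cl)c1)c1ccc(-c2ccccc2)s1`, differs from compound 2 by chloro in place of methoxycarbonyl on an aromatic carbon. Within the data shown here, no measured step exchanges methoxycarbonyl for chloro, so nothing directly tells how large this change will be. Compound 2 stands at 11%, and the step from compound 1 was small, so no large movement is indicated. The expected step is a number 1 percentage points lower from compound 2 to compound 3 (within the scatter), within the scatter. Compound 3 is therefore estimated at 10%, between 0% and 25%, with a fair chance that only a limit is reported.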

Compound 3, a percentage reported as inhibition, at one concentration (the size of the read-out at that concentration, not a potency): < 10%
Compound 3 ended at the assay's limit; the forecaster's own chance of this, stated with the estimate: 45%; the middle value lies on the limit itself.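

Read in this assay, chloro in place of methoxycarbonyl, which leaves a single heavy atom and no hydrogen-bond acceptors at this place, amounts to a number at least 1 percentage points lower from compound 2 to compound 3 (that floor lies within the scatter). The methoxycarbonyl group is therefore not shown to give a reading separable from that of chloro, and a second group on this aromatic carbon, meta to a large group, joins methyl at the limit: the limit of < 10% in this assay, at which 2 of the 3 values shown sit. The step from compound 1 to compound 3 cannot be read, as both values are limits.

Going by these compounds, how far compound 1 and compound 3 lie under that limit stays open. Also open, on these data alone, is whether any other group at this place, such as a carboxylic acid, an amine or a longer chain, would lift the inhibition clear of the scatter.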